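Trimming the Side Chain of a 5-Lipoxygenase Inhibitor

The source may report more compounds than this note shows. Statements on the series, on what has been measured and on what is new or still open speak of the compounds shown alone.

Compound 1 `CC(C)C(C#Cc1cccc(C(=O)NCc2ccccc2C(F)(F)F)c1)N(O)C(N)=O` was tested in an assay for inhibition of Polyunsaturated fatty acid 5-lipoxygenase (Homo sapiens), read by HPLC, with stated times of 15 min and 10 min (on this read-out higher numbers stand for weaker inhibition and lower numbers for stronger inhibition), where compound 1 gives 500 nM. Among the three measured compounds it stands second highest: compound 3 `C[C@H](C#Cc1cccc(C(=O)NCCC(c2ccccc2)c2ccc(Cl)c(Cl)c2)c1)N(O)C(N)=O` gives 96 nM, a clearly lower number, while compound 2 `CC(C#Cc1ccc(C(=O)NCc2ccccc2C(F)(F)F)o1)N(O)C(N)=O` gives 4000 nM, a clearly higher one. Compound 4 `C[C@@H](C#Cc1cccc(C(=O)NCc2ccccc2C(F)(F)F)c1)N(O)C(N)=O` has not yet been measured. It differs from compound 1 in one place, namely (1-(carbamoyl(hydroxy)amino)ethyl in place of 1-(carbamoyl(hydroxy)amino)-2-methylpropyl on a triple-bonded carbon). Among the compounds with values here, no measured pair shows this exact change, so the size of the step is uncertain; a small shift within the usual scatter, in either direction, seems most likely. For compound 4 the expected value is 450 nM, with a likely range from 150 nM to 1400 nM. That estimate means a step from compound 1 to compound 4 of a 1.1-fold lower number from compound 1 to compound 4 (0.05 log units; within the scatter).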

Compound 4, half-maximal inhibitory concentration: 700 nM
Compound 4: the middle estimate sits 1.6-fold (0.19 log units) below what was measured; low and high end bracket the measured number.
By their numbers in this assay, from the lowest: compound 3; then compounds 1 and 4 (each within the scatter of the next); then compound 2.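

In this assay, replacing 1-(carbamoyl(hydroxy)amino)-2-methylpropyl with 1-(carbamoyl(hydroxy)amino)ethyl gives a 1.4-fold higher number from compound 1 to compound 4 (0.15 log units; within the scatter) and so stays within the usual scatter. Within the data shown here, this pair is the first to isolate this position, and on the core of compound 1 the smaller group serves about as well as the larger one. Nothing available explains why the swap leaves the number so little changed.

As far as these compounds go, whether a cyclopropyl group or a longer chain such as butyl at this carbon would keep the number in the same range remains open. So does how the mirror-image form of compound 4, with its one defined stereocentre reversed, would compare.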